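A Second Fluoro Group and Toxicity to Cultured Cells

This account rests on a few compounds, and the source may have more. Where it says the series, first, only, none or still open, it means among the compounds named here.

Three compounds share a core carrying an amide; compound 1 is `Cc1c(C(=O)NCc2ccccc2)[n+]([O-])c2cc(F)c(F)cc2[n+]1[O-]`, compound 2 is `COc1ccc(CNC(=O)c2c(C)[n+]([O-])c3ccc(OC)cc3[n+]2[O-])cc1` and compound 3 is `COc1ccc(CNC(=O)c2c(C)[n+]([O-])c3ccc(F)cc3[n+]2[O-])cc1`. Cytotoxicity toward cultured cells was measured in an ADME assay on Vero cells (Chlorocebus sabaeus) for cytotoxicity, read by MTT assay, with a stated time of 72 h; on this read-out lower numbers stand for stronger inhibition and higher numbers for weaker inhibition. In this assay compound 1 gives 18.4 ug/mL. For compound 2 the result is "not determined" (no result reported), so no number is available. Compound 3 stands apart in that it reaches only a limit of the assay: in this assay compound 3 gives > 30 ug/mL. That places compound 3 at the limit of > 30 ug/mL in this assay, at which 1 of the 3 values shown sits, with no single number to compare against compound 1.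

The unmeasured compound 4 is `COc1ccc(CNC(=O)c2c(C)[n+]([O-])c3cc(F)c(F)cc3[n+]2[O-])cc1`. It differs from compound 3 by fluoro in place of hydrogen on an aromatic carbon. Going by the values given here, no step between measured compounds isolates this change, so its size can only be guessed. The value of compound 1 in this assay shows that a compound with two fluoro groups on the core can give a measurable number, so a step from the limit toward a lower number is expected, of a size that may still lie within the usual scatter. For compound 4 the estimate in this assay is 22 ug/mL, within 10 ug/mL to 45 ug/mL. The expected step is an at least 1.3-fold lower number from compound 3 to compound 4 (0.13 log units; that floor lies within the scatter).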

Compound 4, half-maximal inhibitory concentration: 16.6 ug/mL
Compound 4: the middle estimate sits 1.3-fold (0.12 log units) above what was measured, and the stated range covers the measured number.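

In this assay, going by these compounds alone, the new compound gives the first measured step for fluoro in place of hydrogen on an aromatic carbon, ortho to a fluoro group, in the series with the methoxy-bearing benzyl amide: an at least 1.8-fold lower number from compound 3 to compound 4 (0.25 log units; that floor lies within the scatter). This step is only a floor and not a full size, and even that floor does not clear the normal spread of repeat measurements, since compound 3 has only a limit of the assay rather than a number: the limit of > 30 ug/mL in this assay, at which 1 of the 4 values shown sits. The second comparison is new as well, because it shows what a methoxy group taking the place of a hydrogen does when the core carries two fluoro groups: a 1.1-fold lower number from compound 1 to compound 4 (0.04 log units; within the scatter), so compound 1 and compound 4 cannot be told apart in this test.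

From the compounds shown here alone, the true size of the fluoro step stays open, and steps to compound 2 cannot be read. Nor do the compounds shown tell whether a chloro group, a trifluoromethyl group or an amine at this position would give a number like that of compound 4.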